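A few compounds are considered here, and "the series" means these few. Any claim that something is new, unique, unknown or untested is made for them only; others in the source may bear on it.

Compound 1 `O=C(NCC1CCOCC1)c1cnc(Nc2cc(Cl)cc(Cl)c2)cc1C1CC1` gives 7 ug/mL in a physicochemical assay for solubility, at pH 7.4 (on this read-out lower numbers stand for lower solubility and higher numbers for higher solubility), the lowest of the two numbers measured there. Compound 2 `O=C(NCC1CCOCC1)c1cnc(Nc2cccc(Br)c2)cc1C1CC1` gives 45 ug/mL, and the step of a 6.4-fold higher number from compound 1 to compound 2 (0.81 log units; beyond the scatter) lies beyond the scatter. Compound 3 `O=C(NCC1CCOCC1)c1cnc(Nc2ccc(Cl)cc2Cl)cc1C1CCCC1` reaches only a limit, < 1 ug/mL, as described by the limit of < 1 ug/mL in this assay, at which 1 of the 3 values shown sits.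

Compound 4 `O=C(NCC1CCOCC1)c1cnc(Nc2ccc(Cl)c(Cl)c2)cc1C1CC1` differs from compound 1 in one place (3,4-dichlorophenyl in place of 3,5-dichlorophenyl on a nitrogen on an aromatic ring). Going by the values given here, the only measured step that bears on a change of the phenyl group, a 6.4-fold higher number from compound 1 to compound 2 (0.81 log units; beyond the scatter), removed a chlorine; here the same atoms are merely joined differently. The step of no change at the digits printed from compound 1 to compound 4 (within the scatter) is therefore expected to stay within the scatter. Compound 4 is estimated to give 7 ug/mL, within a range from 2 ug/mL to 20 ug/mL.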

Compound 4, solubility: 6 ug/mL
For compound 4 the middle estimate is 1.2-fold (0.07 log units) above the measured one; low and high end bracket the measured number.
By their numbers in this assay, from the lowest: compounds 4 and 1 (each within the scatter of the next); then compound 2. At a limit, below all of these: compound 3.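

In this assay, the read-out does not separate 3,4-dichlorophenyl from 3,5-dichlorophenyl on a nitrogen on an aromatic ring: a 1.2-fold lower number from compound 1 to compound 4 (0.07 log units; within the scatter). The 3-bromophenyl group stands apart from the 3,4-dichlorophenyl group too, with a 7.5-fold lower number from compound 2 to compound 4 (0.88 log units; beyond the scatter), so both dichlorophenyl compounds lie on the same side of compound 2. Nothing shown gives a cause for either step. As far as these compounds go, what remains open is how a phenyl ring carrying a single chlorine would read in this assay. The same holds for a phenyl ring carrying an amine or a carboxylic acid at this place.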